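The compounds below may be only part of what the source reports. "The series", "measured", "known", "first", "only" and "open" are said of these compounds alone.

The study compares four thiosemicarbazones of a shared core. Compound 1 `CC(=NNC(=S)Nc1cccc([N+](=O)[O-])c1)c1ccccn1` carries a nitro group, and in a functional assay on T98G cells (Homo sapiens) for cytotoxicity, read by MTT assay, with a stated time of 48 h (a higher number here means a weaker inhibitor, a lower number a stronger inhibitor), compound 1 gives 140 nM. Compound 2 `CC(=NNC(=S)Nc1cccc(F)c1)c1ccccn1` differs from it in one place: fluoro in place of nitro on an aromatic carbon, a change that lowered the number a 12-fold lower number from compound 1 to compound 2 (1.07 log units; beyond the scatter); in this assay compound 2 gives 12 nM.

Compound 3 `C/C(=N/NC(=S)Nc1ccc([N+](=O)[O-])cc1)c1ccccn1` is built from the same atoms as compound 1, joined differently, and how the two cores differ is not broken down here. In this assay compound 3 gives 140 nM, which stands level with compound 1 within the usual scatter.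

Compound 4 `C/C(=N/NC(=S)Nc1ccc(F)cc1)c1ccccn1` has not yet been measured. It differs from compound 3 by fluoro in place of nitro on an aromatic carbon. This is the same kind of change as that from compound 1 to compound 2, though not the same: in compound 2 the fluoro sits meta to a large group, in compound 4 it sits para to a large group. Among the compounds with values here, with only one measured example of the change, she expects a step from compound 3 to compound 4 of about a 9.3-fold lower number from compound 3 to compound 4 (0.97 log units; beyond the scatter), resting on the step seen from compound 1 to compound 2 of a 12-fold lower number from compound 1 to compound 2 (1.07 log units; beyond the scatter). Her estimate for compound 4 in this assay is therefore 15 nM, most likely between 5 nM and 50 nM.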

Compound 4, half-maximal inhibitory concentration: 17 nM
The estimate for compound 4 lay 1.1-fold (0.05 log units) below the measured number; the measured number falls inside the stated range.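

In this assay, fluoro in place of nitro gave an 8.2-fold lower number from compound 3 to compound 4 (0.92 log units; beyond the scatter), and set beside the earlier step, the change carried over from one core to the other with no difference in size beyond the scatter: the same change on two cores in this assay, a 12-fold lower number (1.07 log units; beyond the scatter) from compound 1 to compound 2 and an 8.2-fold lower number (0.92 log units; beyond the scatter) from compound 3 to compound 4, 1.4-fold (0.15 log units) apart, within the scatter of two such steps

This shows that, across these two pairs, the swap lowered the number to a similar extent on both cores, so the earlier step was a fair guide to the later one. It does not show why the number falls, whether the loss of nitro or the arrival of fluoro matters more, or that a step of this size would appear on any core beyond these two, as two pairs are a narrow base for a rule.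

Only nitro and fluoro stand on that aromatic ring among the compounds shown, so whether an amine, a methoxy group or a carboxylic acid in the same place would give a comparable number remains open. Also open, going by these compounds, is whether the step between nitro and fluoro would hold on any cell line other than the one used in this assay.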